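Amide-nitrogen substituents: working notes towards compound 4

A few compounds are considered here, and "the series" means these few. Any claim that something is new, unique, unknown or untested is made for them only; others in the source may bear on it.

Measured in an ADME assay on S9 fraction from liver (Homo sapiens) for metabolic stability, with a stated time of 60 min; on this read-out lower numbers stand for a less stable compound and higher numbers for a more stable compound:
- compound 1 `CO[C@H]1CC[C@@H](CN2C(=O)CNc3ncc(-c4ccc(-c5nc[nH]n5)nc4C)nc32)CC1`: 10%
- compound 2 `Cc1nc(-c2nc[nH]n2)ccc1-c1cnc2c(n1)N(C(C)C)C(=O)CN2`: 99%
- compound 3 `Cc1nc(-c2nc[nH]n2)ccc1-c1cnc2c(n1)N([C@H]1CC[C@H](O)CC1)C(=O)CN2`: 97%

Compound 2 belongs to the stable end of this small set. The step to its nearest neighbour is a number 2 percentage points lower from compound 2 to compound 3 (within the scatter), and the step from the other end is a number 89 percentage points higher from compound 1 to compound 2 (beyond the scatter).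

Compound 4 `Cc1nc(-c2nc[nH]n2)ccc1-c1cnc2c(n1)N(CCC1CCOCC1)C(=O)CN2` carries 2-(oxan-4-yl)ethyl in place of isopropyl on an amide-type nitrogen in a ring.

Two measured results frame this change. Compound 3, at 97%, shows that a cyclohexyl-bearing group can leave the number within the scatter of compound 2. Compound 1, at 10%, shows that another such group can go with a large fall. The name of the entering group, like that of the group in compound 1, has a ring on an alkyl link, so a sizeable fall is expected, though smaller than a number 89 percentage points higher from compound 1 to compound 2 (beyond the scatter). Among the measured compounds shown here, the uncertainty remains wide, as only three compounds have been measured.

The expected step is a number 44 percentage points lower from compound 2 to compound 4 (beyond the scatter). For compound 4 the estimated value is 55%, with an expected range of 25% to 85%.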

Compound 4, percent of the compound remaining: 100%
For compound 4 the middle estimate is 45 percentage points below the measured one; the measured number lies above the stated range.
By their numbers in this assay, from the lowest: compound 1; then compounds 3, 2 and 4 (each within the scatter of the next).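

In this assay the step of a number 1 percentage points higher from compound 2 to compound 4 (within the scatter) shows that this amide-type nitrogen in a ring can carry 2-(oxan-4-yl)ethyl, with its 8 heavy atoms, in place of the 3 of isopropyl without a move beyond the scatter. The step of a number 3 percentage points higher from compound 3 to compound 4 (within the scatter) likewise places this group with 4-hydroxycyclohexyl, so compounds 2, 3 and 4 now stand together despite their different groups. The step of a number 90 percentage points higher from compound 1 to compound 4 (beyond the scatter) for (oxan-4-yl)methyl in place of 4-methoxycyclohexyl on a saturated chain carbon shows that a ring on an alkyl link does not by itself go with the low number of compound 1.

What sets the group of compound 1 apart stays unexplained, as nothing at hand bears on it. Also open, as far as these compounds go, is how a longer chain, or an amine or carboxylic acid on this nitrogen's chain, would read in this assay at this position.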